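A few compounds are considered here, and "the series" means these few. Any claim that something is new, unique, unknown or untested is made for them only; others in the source may bear on it.

Measured compounds in an ADME assay on HEL cells (Homo sapiens) for cytotoxicity, with a stated time of 3 days; on this read-out higher numbers stand for lower toxicity in this test and lower numbers for higher toxicity in this test:

- compound 1 `Cc1cn([C@@H]2O[C@H](CO[Si](C)(C)C(C)(C)C(C)C)[C@@]3(OS(=O)(=O)C=C3NC(=O)NC(=O)c3ccccc3)[C@H]2O[Si](C)(C)C(C)(C)C)c(=O)n(C)c1=O`: > 50000 nM
- compound 2 `Cc1cn([C@@H]2O[C@H](COC(=O)c3ccccc3)[C@@]3(OS(=O)(=O)C=C3NC(=O)NC(=O)c3ccccc3)[C@H]2O)c(=O)n(C)c1=O`: > 100000 nM
- compound 3 `Cc1cn([C@@H]2O[C@H](CO[Si](C)(C)C(C)(C)C)[C@@]3(OS(=O)(=O)C=C3NC(=O)Nc3ccccc3)[C@H]2O[Si](C)(C)C(C)(C)C)c(=O)n(C)c1=O`: 1300 nM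

The first two entries are limits of the assay, not numbers. Compound 1 stops at the limit of > 50000 nM in this assay, at which 1 of the 3 values shown sits. Compound 2 stops at the limit of > 100000 nM in this assay, at which 1 of the 3 values shown sits. For the measured compounds named here, compound 3 is therefore the only member of the series with a numerical read-out in this assay, and it stands alone: no pair of measured compounds differs in just one place, so no measured step is available to size any change against.

Compound 4 `CCOC(=O)CNC(=O)NC1=CS(=O)(=O)O[C@@]12[C@@H](CO[Si](C)(C)C(C)(C)C)O[C@@H](n1cc(C)c(=O)n(C)c1=O)[C@@H]2O[Si](C)(C)C(C)(C)C` has not yet been measured in this assay. It differs from compound 3 by (ethoxycarbonyl)methyl in place of phenyl on an amide-type nitrogen. Going by the values given here, with no measured step to lean on, the expectation rests on the structural change alone: the urea is kept, and only the substituent on its outer amide-type nitrogen is exchanged. The step from compound 3 to compound 4 in this assay is estimated at a 3.8-fold higher number from compound 3 to compound 4 (0.59 log units; beyond the scatter), tending toward lower toxicity, though a result inside the usual scatter would not be surprising. Compound 4 is accordingly expected to give about 5000 nM, within a range of 1000 nM to 50000 nM, with a real chance that the assay again reports only a limit.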

Compound 4, half-maximal cytotoxic concentration: 13000 nM
Estimate against measurement, compound 4: 2.6-fold (0.41 log units) below, within the range that was stated.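

In this assay, the outer amide-type nitrogen of the urea proves to be a place where the substituent matters: (ethoxycarbonyl)methyl in place of phenyl gives a 10-fold higher number from compound 3 to compound 4 (1.00 log units; beyond the scatter). For the compounds shown here, this is the first measured single-place step, and it lies beyond the scatter, in the direction of lower toxicity in this test, even though the entering and leaving groups both hold 6 heavy atoms, so the step goes with an exchange of groups of equal heavy-atom count, the aromatic ring leaving and the ester entering. No information at hand bears on the cause of this step.

Going by these compounds alone, the single pair cannot separate the loss of the phenyl ring from the arrival of the ester, and a benzyl group, a plain ethyl chain or the free carboxylic acid, (carboxy)methyl, on the same nitrogen would tell these apart. Within the data shown here, whether the step carries over to the other substituents on the shared core, such as a free hydroxyl or a benzoate ester in place of the silyl ethers, also stays open, since this is the only pair differing in one place.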